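The source may report more compounds than this note shows. Statements on the series, on what has been measured and on what is new or still open speak of the compounds shown alone.

In a functional assay on DU-145 cells (Homo sapiens) for inhibition, read by trypan blue exclusion, with a stated time of 96 h (on this read-out lower numbers stand for stronger inhibition of growth and higher numbers for weaker inhibition of growth), compound 3 (`O=C(/C(=C\c1c(O)cc(O)cc1O)S(=O)(=O)c1ccc(Br)cc1)c1ccc(Cl)cc1`) gives (> 100000 nM), which is a limit and not a number. Compound 4 (`Cc1ccc(S(=O)(=O)/C(=C/c2c(O)cc(O)cc2O)C(=O)c2ccc(Cl)cc2)cc1`) differs from it in one place, with methyl in place of bromo on an aromatic carbon. Compound 1 (`Cc1ccc(S(=O)(=O)/C(=C/c2ccc(O)c([N+](=O)[O-])c2)C(=O)c2ccc(Cl)cc2)cc1`) gives (25000 nM) and compound 2 (`Cc1ccc(S(=O)(=O)/C(=C/c2sccc2C)C(=O)c2ccc(Cl)cc2)cc1`) gives (10000 nM), and both carry the 4-methylphenyl group that compound 4 gains. Within the data shown here, no measured step covers this swap. Among the measured compounds shown here, the one measured step (a 2.5-fold lower number from compound 1 to compound 2 (0.40 log units; beyond the scatter)) is modest and lies elsewhere in the structure, so it offers only a rough guide to size. A similarly modest move to a lower number is expected in this assay, and the estimated step is (an at least 1.6-fold lower number from compound 3 to compound 4 (0.22 log units; that floor lies within the scatter)). Compound 4 is expected at (60000 nM), with an estimated range from (15000 nM) to (200000 nM).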

Compound 4, concentration for 50% growth inhibition: > 100000 nM
Compound 4 gave a limit, no number; the forecaster's own chance of this, stated with the estimate: 45%; at least 1.6-fold (0.22 log units) between middle value and limit.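

Compound 3 and compound 4 both stop at a limit, so the change from bromo to methyl cannot be read in this assay: the limit of > 100000 nM in this assay, at which 2 of the 4 values shown sit. With the 4-methylphenyl group kept in all three compounds, changing only the other aryl group to 2,4,6-trihydroxyphenyl gives an at least 10-fold higher number from compound 2 to compound 4 (1.00 log units; beyond the scatter) and an at least 4.0-fold higher number from compound 1 to compound 4 (0.60 log units; beyond the scatter). Compound 4, with methyl in place of bromo, stops at a limit. The data hold no readable number for it. Going by these compounds, whether bromo and methyl differ on a compound with a readable value remains open. So does the effect of an amine or a carboxylic acid on that aromatic carbon.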